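Fluoro for methyl on a series that sits at the limit

The source may hold more compounds than are shown below. What is called first, only, known or untested is meant among the compounds shown, and "the series" means these compounds.

Compound 1 `CCOC(=O)c1c(C)[nH]c(=O)c(C#N)c1-c1ccccc1` gives > 100000 nM in a functional assay on SK-OV-3 cells (Homo sapiens) for inhibition, read by MTT assay, with a stated time of 24 h (a lower number here means a stronger inhibitor, a higher number a weaker inhibitor), which is a limit of the assay and not a number.
Compound 2 `CCOC(=O)c1c(C)[nH]c(=O)c(C#N)c1-c1ccc(C)cc1` gives > 100000 nM in this assay, likewise a limit.
Compound 3 `CCOC(=O)c1c(C)[nH]c(=O)c(C#N)c1-c1ccc(C#N)cc1` gives > 100000 nM in this assay, again a limit.

Compound 2 therefore stands nowhere in particular on the numbers shown: every value in this assay is a limit, as the limit of > 100000 nM in this assay, at which 3 of the 3 values shown sit, records. The step to the unmeasured compound 4 `CCOC(=O)c1c(C)[nH]c(=O)c(C#N)c1-c1ccc(F)cc1` is fluoro in place of methyl on an aromatic carbon. The measured steps that touch this position are a step that the two limits leave unreadable from compound 2 to compound 3 and, from the parent, a step that the two limits leave unreadable from compound 1 to compound 2 and a step that the two limits leave unreadable from compound 1 to compound 3; none of them can be read, since both ends sit at the limit. Among the compounds with values here, no measured step therefore gives a direction or a size for this assay, and nothing in the set suggests that the change from methyl to fluoro would carry compound 4 below the limit. Compound 4 is expected to give 150000 nM in this assay, with a range from 40000 nM to 600000 nM. That estimate means a step that the limit leaves unreadable from compound 2 to compound 4, which is expected to be no step beyond the scatter at all, and most likely another limit.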

Compound 4, half-maximal inhibitory concentration: > 100000 nM
Compound 4 was reported as a limit; the forecaster's own chance of this, stated with the estimate: 88%; the middle value does not contradict the limit.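

Compound 4 sits at the same limit of the assay as compound 1, compound 2 and compound 3, so none of the steps between them can be read in this assay: the limit of > 100000 nM in this assay, at which 4 of the 4 values shown sit.

The compounds shown leave open how these four rank against one another, and whether any change to the shared core gives a measurable value in this assay.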